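This account rests on a few compounds, and the source may have more. Where it says the series, first, only, none or still open, it means among the compounds named here.

Measured compounds:
- compound 1, `NC(=O)c1cccc(-c2cnc(C(=O)CCCCCCc3ccccc3)o2)c1`, 6 nM in an assay (Rattus norvegicus) for inhibition of Fatty-acid amide hydrolase 1 (Homo sapiens); a lower number here means a stronger inhibitor, a higher number a weaker inhibitor
- compound 2, `COC(=O)c1ccc(-c2cnc(C(=O)CCCCCCc3ccccc3)o2)cc1`, 40 nM in this assay

Of the two measured compounds, compound 2 stands with the higher number in this assay; compound 1 gives 6 nM, and the gap between the two lies beyond the scatter, so compound 1 is the stronger inhibitor here. The two differ in more than one place, so their values show the gap and nothing more.

Compound 3, `O=C(CCCCCCc1ccccc1)c1ncc(-c2ccc(O)cc2)o1`, follows from compound 2 by a single change: hydroxy in place of methoxycarbonyl on an aromatic carbon. A hydroxy in place of methoxycarbonyl on an aromatic carbon is the whole of it; the shared core and the chain ending in a phenyl stay as they are.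

Going by the values given here, no measured pair shows this exact change, so the step can only be expected, not read off. The expectation is a modest move toward a lower number in this assay, a step from compound 2 to compound 3 of about a 2.7-fold lower number from compound 2 to compound 3 (0.43 log units; beyond the scatter). On that basis compound 3 is estimated at 15 nM in this assay, with a range from 4 nM to 60 nM.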

Compound 3, inhibition constant: 140 nM
Estimate against measurement, compound 3: 9.3-fold (0.97 log units) below; the whole stated range lies below it.
By their numbers in this assay, from the lowest: compound 1; then compound 2; then compound 3.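

In this assay, putting hydroxy in place of methoxycarbonyl on the aromatic carbon para to a large group gives a 3.5-fold higher number from compound 2 to compound 3 (0.54 log units; beyond the scatter), so this one place on the ring does affect the number, and here the smaller group, with one heavy atom in place of four, goes with the weaker inhibitor. Changing the whole ring substituent, with 4-hydroxyphenyl in place of 3-carbamoylphenyl, gives a 23-fold higher number from compound 1 to compound 3 (1.37 log units; beyond the scatter), a large step, which shows that among these three compounds the group on this ring can move the number widely while the shared core and the chain ending in a phenyl stay the same. Nothing given here explains what lies behind either step.

As far as these compounds go, how an amine or a carboxylic acid on that same aromatic carbon would compare with hydroxy and methoxycarbonyl remains open. Also open, from the compounds shown here alone, is how much of the gap between compound 1 and compound 3 comes from the group itself and how much from where it sits on the ring, a question that a 4-carbamoylphenyl or a 3-hydroxyphenyl group could help to settle.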